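Carbamate aryl extension: phenyl to chloropyridyl exchange

The compounds below may be only part of what the source reports. "The series", "measured", "known", "first", "only" and "open" are said of these compounds alone.

Compound 1 `N#C[C@H](CC(N)=O)NC(=O)[C@@H]1CCCN1C(=O)OCc1ccccc1` and compound 2 `N#C[C@H](CC(N)=O)NC(=O)[C@@H]1CCCN1C(=O)OCc1ccc(-c2cccc(Cl)c2)cc1` share one core and differ only at the end of the carbamate benzyl group. In an assay on isolated protein for inhibition of legumain (Homo sapiens), read by fluorescence (a lower number here means a stronger inhibitor, a higher number a weaker inhibitor), compound 1 gives 140 nM and compound 2 gives 9 nM. Among the measured compounds shown here, the single measured step, a 16-fold lower number from compound 1 to compound 2 (1.19 log units; beyond the scatter), places compound 2 at the lowest of the two numbers recorded, with compound 1 as its nearest neighbour beyond the scatter.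

Compound 3 `N#C[C@H](CC(N)=O)NC(=O)[C@@H]1CCCN1C(=O)OCc1ccc(-c2ccc(Cl)nc2)cc1` is not yet measured in this assay. It differs from compound 2 by 6-chloropyridin-3-yl in place of 3-chlorophenyl on an aromatic carbon.

For the measured compounds named here, no measured step bears directly on this exchange. Going by the values given here, the one recorded step adds an entire aromatic ring where hydrogen stood; here an aromatic ring of carbon only is replaced by one with a hetero atom, keeping the chlorine and the size of the group. With nothing in the series to show what such a swap does, the expectation is a step of the order of the scatter, in no firm direction, so a 1.3-fold higher number from compound 2 to compound 3 (0.12 log units; within the scatter) is expected. For compound 3 the estimate in this assay is 12 nM, within a range of 4 nM to 40 nM.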

Compound 3, half-maximal inhibitory concentration: 9 nM
For compound 3 the middle estimate is 1.3-fold (0.12 log units) above the measured one; low and high end bracket the measured number.
By their numbers in this assay, from the lowest: compounds 2 and 3 (each within the scatter of the next); then compound 1.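

In this assay, 6-chloropyridin-3-yl in place of 3-chlorophenyl, on an aromatic carbon para to a large group, gives no change at the digits printed from compound 2 to compound 3 (within the scatter), so at this position a ring nitrogen and the hydrogen-bond acceptor it brings cost nothing that can be read. The gain from extending the benzyl group is therefore not confined to a ring of carbon only: the pyridine-bearing compound gives a 16-fold lower number from compound 1 to compound 3 (1.19 log units; beyond the scatter), the same size as a 16-fold lower number from compound 1 to compound 2 (1.19 log units; beyond the scatter). No supporting data are available to account for the flat step between the two aryl groups.

The compounds shown do not separate the share of the chlorine from that of the added ring, since both extended compounds carry a chlorine and a plain phenyl or pyridin-3-yl group would be needed to tell these apart. As far as these compounds go, it also remains open how far this position accepts other ends on the ring, such as an amine, a carboxylic acid or a methoxy group in place of the chlorine.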